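Cytotoxicity at the Ceiling: From Compound 3 to Compound 4

A few compounds are considered here, and "the series" means these few. Any claim that something is new, unique, unknown or untested is made for them only; others in the source may bear on it.

Three analogues built on one shared core have been measured in an ADME assay on MT4 cells (Homo sapiens) for cytotoxicity, read by MTT assay, with a stated time of 4 days (on this read-out lower numbers stand for higher toxicity in this test and higher numbers for lower toxicity in this test), and all three sit at the same limit. Compound 1 `CCOC(=O)c1cnc(N2CCN(Cc3ccc(C#N)cc3)CC2)nc1Oc1c(C)cc(-c2ccc(C#N)cc2)cc1C` returns only a limit in this assay, > 125000 nM. Compound 2 `CCOC(=O)c1cnc(N2CCN(Cc3ccccc3C(F)(F)F)CC2)nc1Oc1c(C)cc(-c2ccc(C#N)cc2)cc1C` likewise gives a limit, > 125000 nM. Compound 3 `CCOC(=O)c1cnc(N2CCN(Cc3cc(F)cc(F)c3)CC2)nc1Oc1c(C)cc(-c2ccc(C#N)cc2)cc1C`, the starting point of the present step, also gives a limit in this assay, > 125000 nM. the limit of > 125000 nM in this assay, at which 3 of the 3 values shown sit, is therefore the whole of what is known: compound 3 stands at the ceiling together with the other two, and no ordering among them can be read. The three measured steps are a step that the two limits leave unreadable from compound 1 to compound 2, a step that the two limits leave unreadable from compound 1 to compound 3 and a step that the two limits leave unreadable from compound 2 to compound 3, each of them unreadable in size because the limit of > 125000 nM in this assay, at which 3 of the 3 values shown sit, covers both of its ends.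

Compound 4 `CCOC(=O)c1ccc(CN2CCN(c3ncc(C(=O)OCC)c(Oc4c(C)cc(-c5ccc(C#N)cc5)cc4C)n3)CC2)cc1` differs from compound 3 in one place: 4-(ethoxycarbonyl)phenyl in place of 3,5-difluorophenyl on a saturated chain carbon bound to an amine nitrogen in a ring. The measured steps bear on this change only in that every exchange of the group on the saturated chain carbon bound to an amine nitrogen in a ring has so far left the read-out at the limit. For the measured compounds named here, no step of readable size exists, so no direction is expected beyond the scatter in this assay. Compound 4 is accordingly expected to sit at the limit as well, estimated at 150000 nM, within 100000 nM to 300000 nM. The expected step is a step that the limit leaves unreadable from compound 3 to compound 4.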

Compound 4, half-maximal cytotoxic concentration: > 125000 nM
Compound 4 ended at the assay's limit; the forecaster's own chance of this, stated with the estimate: 85%; the middle value does not contradict the limit.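

In this assay, for the compounds shown here, no step of readable size links compound 4 with compound 1, compound 2 or compound 3, because all four give only a limit: the limit of > 125000 nM in this assay, at which 4 of the 4 values shown sit.

The compounds shown leave open how far beyond that limit each of the four lies, and whether any group on the saturated chain carbon would bring a readable value.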